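Chromone benzoxazine series: nitro for methoxy at compound 4

The source may hold more compounds than are shown below. What is called first, only, known or untested is meant among the compounds shown, and "the series" means these compounds.

Measured so far in a functional assay on MCF7 cells (Homo sapiens) for inhibition, read by MTT assay, with a stated time of 48 h, tested at 30 ug/mL; on this read-out lower numbers stand for less inhibition of growth and higher numbers for more inhibition of growth at the one concentration tested:
- compound 1 `COc1cccc2c1OCN(c1ccc3oc(-c4ccccc4)cc(=O)c3c1)C2`: 67.8%
- compound 2 `Cc1cc(C)c2c(c1)CN(c1ccc3c(=O)cc(-c4ccccc4)oc3c1)CO2`: 26.8%
- compound 3 `O=c1cc(-c2ccccc2)oc2cc(N3COc4c(cccc4[N+](=O)[O-])C3)ccc12`: 5.65%

Compound 1 stands highest of the three numbers in this assay. Its nearest neighbour is compound 2, whose number lies lower by a margin beyond the scatter, and its furthest is compound 3, lower still and also beyond the scatter. No pair among these three differs in one place only, so no single step within the measured set is defined.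

Compound 4 `O=c1cc(-c2ccccc2)oc2ccc(N3COc4c(cccc4[N+](=O)[O-])C3)cc12` is the next member. It differs from compound 1 in one place: nitro in place of methoxy on an aromatic carbon. The same nitro group is present in compound 3, which gives the lowest number of the set, but compound 3 also differs from compound 4 elsewhere, so its value can only be read as a hint, not as a step.

On that basis the change from compound 1 to compound 4 is expected to lower growth inhibition in this assay by a step beyond the scatter, a number 42.8 percentage points lower from compound 1 to compound 4 (beyond the scatter). Among the measured compounds shown here, for compound 4 the estimate in this assay is 25%, with a plausible range from 5% to 55%; the wide range reflects that compound 3 is the only guide and is not a direct neighbour.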

Compound 4, percent growth inhibition at one concentration: 61.9%
Beside the measured number, compound 4's estimate is 36.9 percentage points below it; measured number outside the range, above it.
By their numbers in this assay, from the lowest: compound 3; then compound 2; then compounds 4 and 1 (each within the scatter of the next).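

Among the compounds shown here, the first single-place step, nitro in place of methoxy on this aromatic carbon, reads in this assay as a number 5.9 percentage points lower from compound 1 to compound 4 (within the scatter) and so gives no separation between the two groups at the one concentration tested. For this position, compound 1 and compound 4 therefore read alike, even though nitro enters with more heavy atoms and more hydrogen-bond acceptors than the methoxy that leaves. No measurement at hand bears on why the two groups read alike.

Going by these compounds, whether the same holds for other groups on this aromatic carbon, such as an amine, a carboxylic acid or a longer alkoxy chain, stays open, as does how a plain hydrogen there would read against methoxy and nitro. The compounds shown also give a single concentration in one cell line, so whether compound 1 and compound 4 stay alike across a full dose-response or in other cells remains undefined.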